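The source may hold more compounds than are shown below. What is called first, only, known or untested is meant among the compounds shown, and "the series" means these compounds.

In an ADME assay on microsomes from liver (Homo sapiens) for metabolic stability, with a stated time of 10 min (a higher number here means that more of the compound is left, a lower number that less of the compound is left), the measured compounds read as follows:

Compound 1 `CC(=O)N1CCC(C(=O)N2C[C@@H](c3ccc(C(O)(C(F)(F)F)C(F)(F)F)cc3)[C@@](C)(c3ccc(F)cc3)C2)CC1`: 86%
Compound 2 `C[C@]1(c2ccc(F)cc2)CN(C(=O)C2CCN(C(=O)C(N)=O)CC2)C[C@H]1c1ccc(C(O)(C(F)(F)F)C(F)(F)F)cc1`: 91%
Compound 3 `C[C@]1(c2ccc(F)cc2)CN(C(=O)C2CCN(C(=O)CO)CC2)C[C@H]1c1ccc(C(O)(C(F)(F)F)C(F)(F)F)cc1`: 86%

Compound 3, at 86%, stands level with compound 1 and within the scatter of compound 2. The next compound, compound 4 `COCC(=O)N1CCC(C(=O)N2C[C@@H](c3ccc(C(O)(C(F)(F)F)C(F)(F)F)cc3)[C@@](C)(c3ccc(F)cc3)C2)CC1`, has methyl in place of hydrogen on an oxygen on a saturated carbon, turning hydroxymethyl into methoxymethyl: methyl in place of hydrogen on an oxygen on a saturated carbon.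

Among the compounds with values here, no measured step makes this exact change. The closest evidence comes from the three steps among the measured compounds: no change at the digits printed from compound 1 to compound 3 (within the scatter), a number 5 percentage points higher from compound 1 to compound 2 (within the scatter) and a number 5 percentage points lower from compound 2 to compound 3 (within the scatter). All three stay within the scatter, so these changes on the same carbonyl carbon give no sign of a large effect in this assay. On that limited evidence, the expected result is no shift beyond the scatter, with a slight downward allowance: a number 3 percentage points lower from compound 3 to compound 4 (within the scatter). For compound 4 the estimated value is 83%, with an expected range of 68% to 93%.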

Compound 4, percent of the compound remaining: 54%
For compound 4 the middle estimate is 29 percentage points above the measured one; measured number below the stated range.
By their numbers in this assay, from the lowest: compound 4; then compounds 1, 3 and 2 (each within the scatter of the next).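

In this assay, methoxy in place of hydroxy on this saturated carbon gives a number 32 percentage points lower from compound 3 to compound 4 (beyond the scatter) and so moves the number beyond the scatter, which none of the earlier changes on this carbonyl carbon did. The other two comparisons agree, with a number 37 percentage points lower from compound 2 to compound 4 (beyond the scatter) and a number 32 percentage points lower from compound 1 to compound 4 (beyond the scatter) in the same assay. Methyl, carbamoyl and hydroxymethyl stay within the scatter of one another, so among the four groups on this carbonyl carbon only methoxymethyl stands apart, and one methyl on the oxygen is enough to separate it from hydroxymethyl.

Nothing measured here accounts for this drop. Going by these compounds, it remains open whether an ethoxymethyl group on the same carbonyl carbon would fall as far, and whether an aminomethyl group or a carboxylic acid would stay with the first three groups or join methoxymethyl.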